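Swapping a Nitrate Tail for a Furoxan Nitrile

This account rests on a few compounds, and the source may have more. Where it says the series, first, only, none or still open, it means among the compounds named here.

Measured compounds:
- compound 1, `COC(=O)C1=C(C)N=C(C)/C(=C(/O)OC)C1c1cccc(OCCO[N+](=O)[O-])c1`: 750 nM
- compound 2, `COC(=O)C1=C(C)N=C(C)/C(=C(/O)OC)C1c1ccccc1OCc1c(C(N)=O)no[n+]1[O-]`: 560 nM

Both compounds were tested in a functional assay (aorta) with Rattus norvegicus as the target, in the presence of a further agent that is not named here; a higher number here means that more compound is needed for the effect, a lower number that less compound is needed. Compound 1 stands at one end of the two numbers, but its gap to compound 2 lies within the usual scatter of repeated measurements, so the two cannot be told apart on this evidence. Going by the values given here, no step between two measured compounds differing in a single place is available, so nothing about the effect of any one change can be read from compound 1 and compound 2 alone.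

Compound 3, `COC(=O)C1=C(C)N=C(C)/C(=C(/O)OC)C1c1cccc(OCc2no[n+]([O-])c2C#N)c1`, has not yet been measured. It differs from compound 1 in one place: a group of 8 heavy atoms (3 carbon, 3 nitrogen, 2 oxygen; one five-membered aromatic ring with 3 hetero atoms) in place of a group of 5 heavy atoms (1 carbon, 1 nitrogen, 3 oxygen; no ring), on a saturated chain carbon bound to an oxygen on an aromatic ring.

Among the compounds with values here, with no measured step to lean on, and with the two known values sitting so close together, the change from compound 1 to compound 3 is expected to move the number by no more than the scatter, in either direction. The expected step is a 1.2-fold lower number from compound 1 to compound 3 (0.06 log units; within the scatter), which stays within that scatter. For compound 3 the estimated value in this assay is 650 nM, with a range from 250 nM to 1700 nM.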

Compound 3, half-maximal effective concentration: 3.3 nM
Compound 3: the middle estimate sits 200-fold (2.29 log units) above what was measured, and the stated range ends above it.
By their numbers in this assay, from the lowest: compound 3; then compounds 2 and 1 (each within the scatter of the next).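

In this assay, going by these compounds alone, the group on a saturated chain carbon bound to an oxygen on an aromatic ring proves to matter far more than the earlier compounds could suggest: putting the five-membered aromatic ring with its nitrile in place of (nitrooxy)methyl gives a 230-fold lower number from compound 1 to compound 3 (2.36 log units; beyond the scatter) with the rest of the molecule unchanged. Until now no change in a single place could be read at all, whereas this step shows that the number responds very strongly to what is attached at this spot, and that a ring-bearing group can take the place of the open nitrooxy chain end with a large gain. No measurement shown here gives a reason for a step of this size.

The step swaps the whole group at once, so the compounds shown cannot say whether the ring alone or the nitrile on it accounts for the change. A close relative of compound 3 with a carboxylic acid or a methyl in place of the nitrile, or with a longer chain leading to the ring, would help to separate these parts.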